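Oxan-4-yl Replacing Pyridin-3-yl on a Second Core

A few compounds are considered here, and "the series" means these few. Any claim that something is new, unique, unknown or untested is made for them only; others in the source may bear on it.

Compound 1 `COc1ccc(-c2c(C)nc3c(NCc4cccnc4)nc(C)cn23)cc1OC` and compound 3 `COc1ccc(-c2c(C)nn3c(NCc4cccnc4)nc(C)nc23)cc1OC` are built on different cores; the difference between the two cores is not broken down here. In a physicochemical assay for lipophilicity, at pH 7.4 (a lower number here means a more polar compound, a higher number a more lipophilic compound), compound 1 gives 4.5, and compound 3 gives 4.5, level with compound 1. Compound 2 `COc1ccc(-c2c(C)nc3c(NCC4CCOCC4)nc(C)cn23)cc1OC` differs from compound 1 by oxan-4-yl in place of pyridin-3-yl on a saturated chain carbon bound to a nitrogen on an aromatic ring; in this assay compound 2 gives 5.2, which is a number 0.70 log units higher from compound 1 to compound 2 (beyond the scatter). Compound 4 `COc1ccc(-c2c(C)nn3c(NCC4CCOCC4)nc(C)nc23)cc1OC` carries the same change on the core of compound 3, namely (oxan-4-yl in place of pyridin-3-yl on a saturated chain carbon bound to a nitrogen on an aromatic ring). For compound 4 a step of a number 0.70 log units higher from compound 3 to compound 4 (beyond the scatter) in this assay is expected, resting on the size of a number 0.70 log units higher from compound 1 to compound 2 (beyond the scatter) seen on the other core. Compound 4 is therefore estimated at 5.2, with the expected range running from 4.7 to 5.7.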

Compound 4, distribution coefficient: 5.1
Estimate against measurement, compound 4: 0.10 log units above; measured number inside the range.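

In this assay the change from pyridin-3-yl to oxan-4-yl gives a number 0.60 log units higher from compound 3 to compound 4 (beyond the scatter), in the same direction as a number 0.70 log units higher from compound 1 to compound 2 (beyond the scatter) on the other core, and both steps lie beyond the scatter. Going by these compounds alone, this shows that the change carries across these two cores, but with only two pairs it shows nothing about any other core. Nothing shown accounts for the step on either core.

The compounds shown leave open whether a piperidine amine, a carboxylic acid or a longer chain in the same place would behave alike on the two cores. They also leave open how the change reads outside this one measurement.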